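A few compounds are considered here, and "the series" means these few. Any claim that something is new, unique, unknown or untested is made for them only; others in the source may bear on it.

Measured compounds:
Compound 1, `CCc1cc(S(=O)(=O)N2C[C@H](c3ccccc3)NC2=O)ccc1NC(=O)OC(C)C`, gives 60 nM in a functional assay on A549 cells (Homo sapiens) for cytotoxicity, read by MTT assay; a lower number here means a stronger inhibitor, a higher number a weaker inhibitor.
Compound 2, `CC1[C@H](c2ccccc2)NC(=O)N1S(=O)(=O)c1ccc(NC(=O)c2ccc([N+](=O)[O-])cc2)c(Cl)c1`, gives > 10000 nM in this assay, which is a limit of the assay rather than a number.

Among the measured compounds shown here, compound 1 is the only compound here with a numerical result; the other value shown sits at the limit of > 10000 nM in this assay, at which 1 of the 2 values shown sits. Compound 3, `CCc1cc(S(=O)(=O)N2C[C@H](c3ccccc3)NC2=O)ccc1NC(=O)c1ccc(N)cc1`, has not been measured in this assay. It differs from compound 1 in one place: 4-aminophenyl in place of isopropoxy on a carbonyl carbon, so that the isopropoxycarbonyl becomes a (4-aminophenyl)carbonyl on the same amide-type nitrogen. For the measured compounds named here, no pair of measured compounds differs in this one place, so there is no measured step to lean on. Compound 2 carries a carbonyl-linked aromatic ring at the same nitrogen, but it also differs elsewhere, so its limit only shows that such compounds can lose activity. The step from compound 1 to compound 3 is expected to be a modest loss, a 3.3-fold higher number from compound 1 to compound 3 (0.52 log units; beyond the scatter), larger than the scatter. Compound 3 is therefore estimated at 200 nM, with a range from 40 nM to 2000 nM.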

Compound 3, half-maximal inhibitory concentration: 220 nM
For compound 3 the middle estimate is 1.1-fold (0.04 log units) below the measured one; the measured number falls inside the stated range.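

In this assay, putting 4-aminophenyl in place of isopropoxy on the carbonyl carbon gives a 3.7-fold higher number from compound 1 to compound 3 (0.56 log units; beyond the scatter), a modest loss that lies beyond the scatter. Among the compounds shown here, this is the first measured step at this position, and it shows that the position is sensitive to this change. It also shows that a (4-aminophenyl)carbonyl on this nitrogen still leaves a numerical result, with compound 3 at 220 nM. No measurement shown here accounts for the size of this step.

The compounds shown leave open how much of the step belongs to the aromatic ring and how much to its amine, which a plain phenyl or a ring bearing a carboxylic acid instead would help to separate. As far as these compounds go, it also remains open how a longer chain in place of isopropoxy would fare.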